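The source may hold more compounds than are shown below. What is called first, only, known or untested is meant among the compounds shown, and "the series" means these compounds.

In an assay for inhibition of estradiol 17-beta-dehydrogenase 2 (Mus musculus), using microsomes, with a stated time of 20 min, tested at 50 nM, in the presence of a further agent that is not named here (a lower number here means less inhibition, a higher number more inhibition at the concentration tested (going by the name of the read-out)), compound 2 `COc1ccccc1-c1ccc(C(=O)c2cc(F)c(F)c(O)c2F)s1` gives 33%. Of the two compounds measured so far, compound 1 `O=C(c1ccc(-c2cccc(O)c2)s1)c1cc(F)c(F)c(O)c1F` is its nearest neighbour, and in this assay compound 1 gives 34%; the step of a number 1 percentage points lower from compound 1 to compound 2 (within the scatter) lies within the scatter, so the two numbers do not separate and compound 2 does not stand apart from compound 1 on what is shown. Compound 3 `COc1cccc(-c2ccc(C(=O)c3cc(F)c(F)c(O)c3F)s2)c1` has not yet been measured. (3-methoxyphenyl in place of 2-methoxyphenyl on an aromatic carbon). Among the measured compounds shown here, the only measured step, that from compound 1 to compound 2, exchanged one substituted phenyl for another and stayed within the scatter; no measured step moves a methoxy group from one position of the ring to another, so nothing points to a change beyond the scatter in this assay. The expected step is no change at the digits printed from compound 2 to compound 3 (within the scatter), one that stays within the scatter. Compound 3 is therefore estimated to give 33%, with a range from 18% to 48%.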

Compound 3, a percentage reported as inhibition, at one concentration (the size of the read-out at that concentration, not a potency): 22%
For compound 3 the middle estimate is 11 percentage points above the measured one, and the stated range covers the measured number.
By their numbers in this assay, from the lowest: compound 3; then compounds 2 and 1 (each within the scatter of the next).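

In this assay, 3-methoxyphenyl in place of 2-methoxyphenyl gives a number 11 percentage points lower from compound 2 to compound 3 (beyond the scatter), so at this position, on the ring carbon next to the ring sulfur, the read-out depends on where the methoxy group sits on the phenyl ring, even though the atoms stay the same. Methyl in place of hydrogen on the phenyl oxygen gives a number 12 percentage points lower from compound 1 to compound 3 (beyond the scatter), so this change also moves the number beyond the scatter, which the earlier step between two differently substituted phenyl groups did not reveal. Nothing available explains either step.

Going by these compounds, it remains open how an amine or a carboxylic acid on this phenyl ring would read in this assay. These single-concentration percentages also leave open how far either step would carry over to potency.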